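Silyl ether in place of acetyl on the shared core

The source may hold more compounds than are shown below. What is called first, only, known or untested is meant among the compounds shown, and "the series" means these compounds.

Measured in a functional assay on MCF7 cells (Homo sapiens) for cytotoxicity, read by sulforhodamine B assay; on this read-out lower numbers stand for an effect already at smaller amounts and higher numbers for an effect only at larger amounts of compound
compound 1 (`C=C1CC[C@@H]2[C@](C)(COC(C)=O)[C@H](OC(C)=O)CC[C@@]2(C)[C@@H]1C/C=C1/C(=O)OC[C@H]1OC(C)=O`) gives 10 uM
compound 2 (`C=C1CC[C@@H]2[C@](C)(CO[Si](c3ccccc3)(c3ccccc3)C(C)(C)C)[C@H](OC(C)=O)CC[C@@]2(C)[C@@H]1C/C=C1/C(=O)OC[C@H]1O`) gives 7.53 uM

Within the data shown here, compound 1 and compound 2 lie within the scatter of each other, so compound 1 stands level with the only other number available. Compound 3 (`C=C1CC[C@@H]2[C@](C)(CO[Si](C(C)C)(C(C)C)C(C)C)[C@H](OC(C)=O)CC[C@@]2(C)[C@@H]1C/C=C1/C(=O)OC[C@H]1OC(C)=O`) has no value yet. It departs from compound 1 in one place, on an oxygen on a saturated carbon (a group of 10 heavy atoms (9 carbon, 1 silicon; no ring) in place of a group of 3 heavy atoms (2 carbon, 1 oxygen; no ring), on an oxygen on a saturated carbon), where the acetyl leaves and a group with silicon enters. No large step is expected in this assay since compound 2 with silicon on that oxygen gives 7.53 uM while differing from compound 1 elsewhere too. The expected step is small (a 1.3-fold lower number from compound 1 to compound 3 (0.10 log units; within the scatter)) and remains uncertain. For compound 3 the estimate is 8 uM with an expected range of 3 uM to 20 uM for the coming measurement.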

Compound 3, concentration for half-maximal effect: 14 uM
Compound 3: middle estimate off by 1.8-fold (0.24 log units), on the low side; low and high end bracket the measured number.
By their numbers in this assay, from the lowest: compounds 2, 1 and 3 (each within the scatter of the next).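

In this assay, exchanging the acetyl on the oxygen on a saturated carbon for a group of 10 heavy atoms (9 carbon, 1 silicon; no ring) gives a 1.4-fold higher number from compound 1 to compound 3 (0.15 log units; within the scatter) as a change in one place. Among these compounds, this is the first comparison that isolates this oxygen, and compound 3 stands level with compound 1 despite the much larger group with silicon. Nothing measured on these compounds speaks to why the read-out stays level.

Going by these compounds, whether a free hydroxyl, a methyl ether or a chain carrying an amine on this oxygen would also stay level remains open. The separate contribution of the hydroxyl on the other side of compound 2 also cannot be read, since that compound differs from the others in more than one place.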